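The source may hold more compounds than are shown below. What is called first, only, known or untested is meant among the compounds shown, and "the series" means these compounds.

In a functional assay on A549 cells (Homo sapiens) for cytotoxicity, read by MTT assay, with a stated time of 72 h (a higher number here means a weaker inhibitor, a lower number a stronger inhibitor), compound 3 (`C#Cc1cccc(Nc2ncnc3oc(C)c(C(=O)OCC)c23)c1`) gives only a limit (> 1000000 nM) and no number. Compound 1 (`CCOC(=O)c1c(C)oc2ncnc(Nc3cccc(C)c3)c12`) likewise gives only a limit (> 1000000 nM). Going by the values given here, the only measured step nearby is a step that the two limits leave unreadable from compound 1 to compound 3 and it offers no size to carry over. Compound 4 (`CCOC(=O)c1c(C)oc2ncnc(Nc3cccc(Br)c3)c12`) changes one group of compound 3: bromo in place of ethynyl on an aromatic carbon (3-ethynylphenyl to 3-bromophenyl). Compound 2 (`Cc1oc2ncnc(Nc3cccc(Br)c3)c2c1C(=O)O`) carries the same 3-bromophenyl group and gives a real number (43000 nM) but differs from compound 4 elsewhere. Compound 4 is expected to stay weak because the limit of > 1000000 nM in this assay, at which 2 of the 3 values shown sit, holds both its closest neighbours, with any shift towards stronger inhibition. The expected move is an at least 2.5-fold lower number from compound 3 to compound 4 (0.39 log units; beyond the scatter) in this estimate. For compound 4 the estimated value is 400000 nM (range 50000 nM to 1000000 nM).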

Compound 4, half-maximal inhibitory concentration: > 1000000 nM
Compound 4: no number, only a limit; the forecaster's own chance of this, stated with the estimate: 55%; at least 2.5-fold (0.39 log units) between middle value and limit.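

In this assay compound 4 gives only a limit, > 1000000 nM, so bromo on this aromatic carbon shows no readable gain, and the steps linking compound 1, compound 3 and compound 4 cannot be read. Going by these compounds alone, the one readable step is an at least 23-fold higher number from compound 2 to compound 4 (1.36 log units; beyond the scatter), with ethyl in place of hydrogen on an oxygen next to a carbonyl group, so with 3-bromophenyl held constant this other site separates a number from a limit. All three ethyl-bearing compounds now sit together: the limit of > 1000000 nM in this assay, at which 3 of the 4 values shown sit.

From the compounds shown here alone, it remains open whether hydrogen in place of ethyl would also give a number with 3-ethynylphenyl. Going by these compounds, it is equally open how an amine or a longer chain in place of ethyl would read.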